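This account rests on a few compounds, and the source may have more. Where it says the series, first, only, none or still open, it means among the compounds named here.

Measured compounds:
Compound 1, `COc1ccc(C2N=C(SCc3cccc(Cl)c3)NC(C)=C2C(=O)Nc2ccc(Br)cc2)cc1`, gives 27.3% in a functional assay on the whole organism (artery, strain albino) with Rattus norvegicus as the target, with a stated time of 180 min, at a dose of 10 mg/kg by the oral route; a higher number here means more inhibition at the dose given (going by the name of the read-out), a lower number less inhibition.
Compound 2, `CC1=C(C(=O)Nc2ccc([N+](=O)[O-])cc2)C(c2ccc(Br)cc2)N=C(SCc2ccccc2)N1`, gives 19.6%.
Compound 3, `CC1=C(C(=O)Nc2ccc([N+](=O)[O-])cc2)C(c2cccc([N+](=O)[O-])c2)N=C(SCc2ccccc2)N1`, gives 16.5%.

Compound 3 stands lowest of the three numbers. For the measured compounds named here, its nearest neighbour is compound 2, and the only single-place step among the measured compounds, a number 3.1 percentage points lower from compound 2 to compound 3 (within the scatter), lies within the scatter. Compound 1, the furthest, is separated from compound 3 by a gap beyond the scatter, but compound 1 differs from compound 3 in more than one place, so its higher number cannot be tied to any single change.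

The unmeasured compound 4, `CC1=C(C(=O)Nc2ccc([N+](=O)[O-])cc2)C(c2cccc([N+](=O)[O-])c2)N=C(SCc2cccc(Cl)c2)N1`, differs from compound 3 in one place: chloro in place of hydrogen on an aromatic carbon. Going by the values given here, no measured step isolates this change. Compound 1 does carry a chloro on its benzylsulfanyl group and gives the highest value, yet its other differences from compound 3 leave that observation uninformative for the change alone. The step that is measured, from compound 2 to compound 3, concerns a different position and was within the scatter.

Compound 4 is therefore expected to sit close to compound 3, at an estimated 19%, with a range from 8% to 30%. The expected step of a number 2.5 percentage points higher from compound 3 to compound 4 (within the scatter) is estimated to stay within the scatter.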

Compound 4, a percentage reported as inhibition, in the whole organism at one dose (the size of the read-out at that dose, not a potency): 14.9%
The estimate for compound 4 lay 4.1 percentage points above the measured number, and the stated range covers the measured number.
By their numbers in this assay, from the lowest: compounds 4, 3, 2 and 1 (each within the scatter of the next, the first and the last beyond it).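

The change at the benzylsulfanyl group, chloro in place of hydrogen on an aromatic carbon, gives in this assay a number 1.6 percentage points lower from compound 3 to compound 4 (within the scatter), so going from benzylsulfanyl to (3-chlorobenzyl)sulfanyl produces no difference that can be told from the usual scatter on the core of compound 3. For the compounds shown here, this is the first single-place reading at this end of the molecule, since the earlier step concerned the aryl group on the saturated ring carbon, and the two single-place steps now available, at two separate positions, both lie within the scatter. No measurement at hand speaks to the reason for this result.

As far as these compounds go, it remains open whether a methoxy group, an amine or a carboxylic acid on this same aromatic ring, or a longer chain such as phenethyl in place of benzyl, would give a step beyond the scatter. From the compounds shown here alone, it also remains open whether the same chloro change would read alike on the core of compound 2, where 4-bromophenyl sits on the saturated ring carbon, and which single change carries the gap to compound 1.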